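Furan Esters and Amides on a Naphthalene Core: a Bromomethyl Analogue

The source may hold more compounds than are shown below. What is called first, only, known or untested is meant among the compounds shown, and "the series" means these compounds.

Compound 1 `CCCOC(=O)c1c(C)coc1-c1ccc2c(CC)cccc2c1OC`: in a functional assay on MDA-MB-231 cells (Homo sapiens) for cytotoxicity, read by MTT assay, with a stated time of 72 h (a lower number here means that less compound is needed, a higher number that more compound is needed for the effect), compound 1 gives > 10 ug/mL, a limit of the assay.
Compound 2 `CCc1cccc2c(OC)c(-c3occ(C)c3C(=O)NC)ccc12`: in this assay compound 2 gives > 10 ug/mL, likewise a limit.
Compound 3 `CCc1cccc2c(OC)c(-c3occ(C)c3C(=O)On3nnc4ccccc43)ccc12`: in this assay compound 3 gives > 10 ug/mL, again a limit.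

Compound 2 thus stands at the limit only; no number is known for it, and the same holds for the other two measured compounds (the limit of > 10 ug/mL in this assay, at which 3 of the 3 values shown sit). The unmeasured compound 4 `CCc1cccc2c(OC)c(-c3occ(C)c3CBr)ccc12` differs from compound 2 by bromomethyl in place of methylcarbamoyl on an aromatic carbon, the aromatic carbon being one of a five-membered aromatic ring with 1 oxygen, two ring bonds from the ring oxygen. The steps that involve compound 2 are a step that the two limits leave unreadable from compound 1 to compound 2 and a step that the two limits leave unreadable from compound 2 to compound 3; both are unreadable because every value sits at the limit (the limit of > 10 ug/mL in this assay, at which 3 of the 3 values shown sit). Among the compounds with values here, no measured step therefore tells whether changing the group on this carbon shifts the read-out in either direction. Compound 4 is estimated to give 8 ug/mL, with a range from 1.5 ug/mL to 30 ug/mL. This corresponds to an expected step of an at least 1.2-fold lower number from compound 2 to compound 4 (0.09 log units; that floor lies within the scatter), which is itself only an estimate.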

Compound 4, concentration for half-maximal effect: 4.6 ug/mL
Compound 4: middle estimate off by 1.7-fold (0.24 log units), on the high side, and the stated range covers the measured number.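

In this assay, within the data shown here, bromomethyl on this aromatic carbon gives the first readable steps at the position: an at least 2.1-fold lower number from compound 2 to compound 4 (0.33 log units; beyond the scatter) with bromomethyl in place of methylcarbamoyl, and an at least 2.1-fold lower number from compound 1 to compound 4 (0.33 log units; beyond the scatter) with bromomethyl in place of propoxycarbonyl. Compound 4 is thus the only compound shown with a number rather than a limit, so the group on this carbon can shift the read-out downward. The steps among the other three compounds still cannot be read, because each of their values is a limit: the limit of > 10 ug/mL in this assay, at which 3 of the 4 values shown sit.

From the compounds shown here alone, both readable steps are only floors, so their true size stays open. Also open, going by these compounds, is whether the bromine itself is needed, or whether hydroxymethyl, chloromethyl or aminomethyl on this carbon would give a similar number.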